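A few compounds are considered here, and "the series" means these few. Any claim that something is new, unique, unknown or untested is made for them only; others in the source may bear on it.

Measured so far:
compound 1, `C=C[C@@H]1OC(c2ccc(-c3ccccc3)cc2)=N[C@H]1CO`: 24000 nM
compound 2, `C=C[C@@H]1OC(c2ccc(-c3ccccc3)cc2)=N[C@H]1SC(C)=O`: 81000 nM

In an assay on isolated protein for inhibition of matrix metalloproteinase-9 (Homo sapiens) (a lower number here means a stronger inhibitor, a higher number a weaker inhibitor), compound 1 gives 24000 nM, the lowest of the two numbers, and compound 2 gives 81000 nM. Within the data shown here, the one measured step, a 3.4-fold higher number from compound 1 to compound 2 (0.53 log units; beyond the scatter), changes a group on a saturated ring carbon. Compound 3, `C=C[C@@H]1OC(c2ccc(Oc3ccccc3)cc2)=N[C@H]1CO`, differs from compound 1 elsewhere: phenoxy in place of phenyl on an aromatic carbon, on an aromatic carbon para to a group of 9 heavy atoms. Among the measured compounds shown here, no measured step touches that part of the core, so the one known step gives little guidance, and a change within the scatter, or at most modest, is expected: a 2.0-fold lower number from compound 1 to compound 3 (0.30 log units; within the scatter). For compound 3 the estimated value in this assay is 12000 nM, with a range from 3000 nM to 50000 nM.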

Compound 3, inhibition constant: 32000 nM
For compound 3 the middle estimate is 2.7-fold (0.43 log units) below the measured one; low and high end bracket the measured number.
By their numbers in this assay, from the lowest: compounds 1 and 3 (each within the scatter of the next); then compound 2.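

In this assay, phenoxy in place of phenyl on this aromatic carbon gives a 1.3-fold higher number from compound 1 to compound 3 (0.12 log units; within the scatter), so compound 1 and compound 3 cannot be told apart. The added oxygen and the extra heavy atom thus leave the result within the scatter, which the earlier step, made on a saturated ring carbon, could not show. Nothing measured here explains this result. Still open, from the compounds shown here alone, is whether an amine or a carboxylic acid on this aromatic carbon would give a step beyond the scatter. Also open, going by these compounds, is whether phenoxy would behave alike with acetylsulfanyl in place of hydroxymethyl.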